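The source may hold more compounds than are shown below. What is called first, only, known or untested is meant among the compounds shown, and "the series" means these compounds.

Measured so far:
compound 1 `Cc1oc(-c2c(Cl)cccc2Br)nc1CN1CCC(C(=O)NCCCN2C[C@H](C)C[C@H](C)C2)CC1` — > 83 ug/mL
compound 2 `Cc1cccc(Cl)c1-c1nc(CN2CCC(C(=O)NCCCN3CCCC(C)C3)CC2)c(C)o1` — 52.6 ug/mL

In a physicochemical assay for solubility, in phosphate buffer, measured as kinetic solubility, at pH 7.4 (on this read-out lower numbers stand for lower solubility and higher numbers for higher solubility), compound 1 gives > 83 ug/mL; this is a limit of the assay, not a number, and the limit of > 83 ug/mL in this assay, at which 1 of the 2 values shown sits, marks it. Compound 2 gives 52.6 ug/mL in this assay. Compound 3 `Cc1ccc(-c2nc(CN3CCC(C(=O)NCCCN4C[C@H](C)C[C@H](C)C4)CC3)c(C)o2)c(C)c1` differs from compound 1 by 2,4-dimethylphenyl in place of 2-bromo-6-chlorophenyl on an aromatic carbon. Within the data shown here, no measured pair covers this change, so the expectation rests on the two values above alone. The step of an at least 1.1-fold lower number from compound 1 to compound 3 (0.07 log units; that floor lies within the scatter) is expected to stay within the usual scatter, in no set direction. Compound 3 is estimated at 70 ug/mL, with a range from 30 ug/mL to 150 ug/mL.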

Compound 3, solubility: > 71 ug/mL
Compound 3 ended at the assay's limit (the forecaster's own chance of this, stated with the estimate: 40%); at least 1.0-fold (0.00 log units) between middle value and limit.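

Among these compounds, compound 1 and compound 3 both stand at limits of this assay, not at numbers; no step between them can be read. The compounds shown leave open how 2,4-dimethylphenyl and 2-bromo-6-chlorophenyl compare on this read-out.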